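Aryl ether pyrrolidine acids: adding a second ring

The source may report more compounds than this note shows. Statements on the series, on what has been measured and on what is new or still open speak of the compounds shown alone.

Measured set:
compound 1, `Cc1ccccc1Oc1ccc(N2CCC[C@H]2CC(=O)O)cc1`, 74 nM
compound 2, `Cc1cccc(Oc2ccc(N3CCC[C@H]3CC(=O)O)cc2)c1`, 260 nM
compound 3, `O=C(O)C[C@@H]1CCCN1c1ccc(Oc2ccccc2-c2ccccc2)cc1`, 3500 nM

In a functional assay on cells for agonist activity at Free fatty acid receptor 1 (Homo sapiens), read by FLIPR and calcium flux, with a stated time of 100 s (on this read-out lower numbers stand for an effect already at smaller amounts and higher numbers for an effect only at larger amounts of compound), compound 1 gives the lowest number of the three. Its nearest neighbour is compound 2, reached by a 3.5-fold higher number from compound 1 to compound 2 (0.55 log units; beyond the scatter); the furthest is compound 3, reached by a 47-fold higher number from compound 1 to compound 3 (1.67 log units; beyond the scatter). Both steps lie beyond the scatter, so within this small set compound 1 is the most potent.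

Compound 4, `COc1ccc(F)c(-c2cccc(Oc3ccc(N4CCC[C@H]4CC(=O)O)cc3)c2C)c1`, keeps the methyl of compound 1 and carries in addition (2-fluoro-5-methoxyphenyl in place of hydrogen on an aromatic carbon). The step from compound 1 to compound 3 is the closer precedent: there a phenyl entered on an aromatic carbon in place of the methyl, and the number rose by a large amount. The step from compound 1 to compound 2 shows that moving a single methyl on the same ring already costs a modest amount. Neither step is the same change as in compound 4, where the methyl stays and a substituted ring is added next to it, so the weight of compound 3 is uncertain.

For compound 4 in this assay the number is expected to rise, estimated as a 4.1-fold higher number from compound 1 to compound 4 (0.61 log units; beyond the scatter), giving 300 nM with a range from 60 nM to 1500 nM.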

Compound 4, half-maximal effective concentration: 310 nM
Compound 4: the middle estimate sits 1.0-fold (0.01 log units) below what was measured, within the range that was stated.
By their numbers in this assay, from the lowest: compound 1; then compounds 2 and 4 (each within the scatter of the next); then compound 3.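

In this assay, placing 2-fluoro-5-methoxyphenyl on the aromatic carbon ortho to a methyl group and meta to a large group gives a 4.2-fold higher number from compound 1 to compound 4 (0.62 log units; beyond the scatter), a modest loss that lies beyond the scatter. The earlier phenyl change, made in place of the methyl, gave a 47-fold higher number from compound 1 to compound 3 (1.67 log units; beyond the scatter), a large step, so the shared core can carry a second aromatic ring with only a modest cost in at least one arrangement, the one in which the methyl stays. Nothing available explains the difference between these two changes.

The compounds shown leave open how much of the step belongs to the ring itself and how much to its fluorine and methoxy substituents, a question that a plain phenyl at this same carbon with the methyl kept, or a ring carrying only one of the two substituents, would address. Also open, as far as these compounds go, is whether a smaller group at this carbon, such as a chlorine, a hydroxyl or an aminomethyl group, would stay closer to compound 1 than the full ring does.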